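The source may hold more compounds than are shown below. What is called first, only, known or untested is meant among the compounds shown, and "the series" means these compounds.

Working notes on the series.

Compound 1 `O=C(C1CCCCC1)N1CCC(C(=O)N2N=CCC2c2ccccc2)CC1` is the cyclohexylcarbonyl member of the set. In a physicochemical assay for lipophilicity, read by HPLC, measured as chromatographic lipophilicity, at pH 7.4 (a higher number here means a more lipophilic compound, a lower number a more polar compound), compound 1 gives 5.4, the highest of the three numbers in hand. Compound 2 `O=C(c1cscn1)N1CCC(C(=O)N2N=CC[C@H]2c2ccccc2)CC1` carries a thiazole on the same carbonyl carbon and gives 3 in this assay. Compound 3 `O=C(c1cnco1)N1CCC(C(=O)N2N=CC[C@H]2c2ccccc2)CC1` carries an oxazole there and gives 2.7 in this assay. Within the data shown here, the only single-point step between measured compounds is a number 0.30 log units lower from compound 2 to compound 3 (within the scatter), so the two five-membered heteroaryl groups read as the same within the scatter. Against compound 1, the values of compound 2 and compound 3 both sit well below, beyond the scatter.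

Compound 4 `O=C(c1cccnc1)N1CCC(C(=O)N2N=CCC2c2ccccc2)CC1` is not yet measured. The change from compound 1 is pyridin-3-yl in place of cyclohexyl on a carbonyl carbon. Among the measured compounds shown here, no measured step covers an aromatic six-membered ring with one nitrogen on this carbonyl carbon; the nearest information is the distance between compound 1 and the two heteroaryl members. On that basis a large downward step in this assay is expected, of about a number 2.20 log units lower from compound 1 to compound 4 (beyond the scatter). For compound 4 the estimate in this assay is therefore 3.2, with a range from 2.6 to 3.8.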

Compound 4, distribution coefficient: 2.6
Beside the measured number, compound 4's estimate is 0.60 log units above it; low and high end bracket the measured number.
By their numbers in this assay, from the lowest: compounds 4, 3 and 2 (each within the scatter of the next, the first and the last beyond it); then compound 1.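

Among these compounds, the step of a number 2.80 log units lower from compound 1 to compound 4 (beyond the scatter) is the first measured single-place change away from cyclohexyl on this carbonyl carbon, and in this assay it is large. Compounds 2 and 3 are drawn with a defined configuration in the core that compounds 1 and 4 do not carry, so neither forms a one-place pair with compound 1, and this step alone gives a clean size for leaving cyclohexyl. The two groups have the same heavy-atom count and both are six-membered rings, so a change of this size at this position does not require a change in either count; the exchange does replace a non-aromatic ring of carbon only with an aromatic ring holding a nitrogen and a hydrogen-bond acceptor, and nothing measured here says what lies behind the step.

On these data alone, what remains open is how the step divides between the aromatic ring and its nitrogen, which a plain phenyl group on the same carbonyl carbon would begin to separate. Also open, as far as these compounds go, is whether pyridin-2-yl or pyridin-4-yl would give a step of similar size, or whether a saturated ring with a nitrogen, such as tetrahydropyranyl's nitrogen counterpart piperidinyl, would follow it.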